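The compounds below may be only part of what the source reports. "The series", "measured", "known", "first", "only" and "open" are said of these compounds alone.

Of the compounds shown here, three that share one core have been measured in an ADME assay on HepG2 2.2.15 cells (Homo sapiens) for cytotoxicity (on this read-out higher numbers stand for lower toxicity in this test and lower numbers for higher toxicity in this test), so far. Compound 1 (`CCCC(=O)OCCc1c(-c2ccccc2Cl)c2cc(Cl)ccc2[nH]c1=O`), with propyl on a carbonyl carbon, gives 52000 nM there. Compound 2 (`O=C(OCCc1c(-c2ccccc2Cl)c2cc(Cl)ccc2[nH]c1=O)C1CCCC1`), with cyclopentyl in that place, gives 46000 nM in the same test, and compound 3 (`O=C(OCCc1c(-c2ccccc2Cl)c2cc(Cl)ccc2[nH]c1=O)C1CCCCC1`), with cyclohexyl, gives 38000 nM in it too. Compound 3 thus stands level with the other two, its number lying within the scatter of both.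

Compound 4 (`CC12CCC(C(=O)OCCc3c(-c4ccccc4Cl)c4cc(Cl)ccc4[nH]c3=O)(OC1=O)C2(C)C`) keeps the core and changes only the group on the carbonyl carbon (a group of 11 heavy atoms (9 carbon, 2 oxygen; one five-membered non-aromatic ring of carbon only, one five-membered non-aromatic ring with 1 hetero atom) in place of a group of 6 heavy atoms (6 carbon; one six-membered non-aromatic ring of carbon only), on a carbonyl carbon). The entering group has more heavy atoms than cyclohexyl and, unlike it, holds a ring with a hetero atom and hydrogen-bond acceptors.

Among the compounds with values here, three measured steps bear on this change: a 1.1-fold lower number from compound 1 to compound 2 (0.05 log units; within the scatter) and a 1.4-fold lower number from compound 1 to compound 3 (0.14 log units; within the scatter) and also a 1.2-fold lower number from compound 2 to compound 3 (0.08 log units; within the scatter) all stayed within the scatter. None of them brought a hetero atom into the group, so they cover this change only in part. The step expected in this assay is a 1.2-fold higher number from compound 3 to compound 4 (0.07 log units; within the scatter) and so none beyond the scatter in either direction. For compound 4 the estimate is 45000 nM with an expected range from 22000 nM to 90000 nM in this test.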

Compound 4, half-maximal cytotoxic concentration: > 1800000 nM
Compound 4: no number, only a limit; the forecaster's own chance of this, stated with the estimate: 15%; middle value at least 40-fold (1.60 log units) away from the limit.
By their numbers in this assay, from the lowest: compounds 3, 2 and 1 (each within the scatter of the next). At a limit, above all of these: compound 4.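

In this assay the entry for compound 4 is a limit and not a number: the limit of > 1800000 nM in this assay, at which 1 of the 4 values shown sits. Even so, the position on the carbonyl carbon proves far more responsive than propyl, cyclopentyl and cyclohexyl suggested, with an at least 47-fold higher number from compound 3 to compound 4 (1.67 log units; beyond the scatter), an at least 39-fold higher number from compound 2 to compound 4 (1.59 log units; beyond the scatter) and an at least 34-fold higher number from compound 1 to compound 4 (1.53 log units; beyond the scatter), all three large and beyond the scatter, whereas the steps among the earlier compounds all stayed within it. The group that enters in compound 4 has more heavy atoms than the groups with carbon only, and it also holds a five-membered non-aromatic ring with 1 hetero atom and hydrogen-bond acceptors, so this position can carry a change that moves the read-out strongly towards lower toxicity in this test.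

The compounds shown leave open which of these features goes with the shift, since size and hetero atom change together in the single step: a large group of carbon only, such as adamantyl, and a small ring with oxygen, such as tetrahydrofuranyl, would separate the two. As far as these compounds go, how far the true value of compound 4 lies past its limit also stays open, so the full size of these steps is unknown.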